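Cytotoxicity Notes on a Chloroaryl Swap in Two Series

A few compounds are considered here, and "the series" means these few. Any claim that something is new, unique, unknown or untested is made for them only; others in the source may bear on it.

Measured so far:
Compound 1 `COc1cc(OC)c2c(=O)cc(-c3ccc(OCc4cn(-c5ccc(Cl)cc5)nn4)c(OC)c3)oc2c1` gives in an ADME assay on Huh-7 cells (Homo sapiens) for cytotoxicity, read by MTT assay, with a stated time of 72 h; a higher number here means that more compound is tolerated, a lower number that less compound is tolerated > 100 ug/mL, which is a limit of the assay.
Compound 2 `COc1cc(OC)c2c(=O)cc(-c3ccc(OCc4cn(-c5ccc(F)cc5Cl)nn4)c(OC)c3)oc2c1` gives in this assay > 100 ug/mL, also a limit.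
Compound 3 `COc1cc(O)c(C(=O)/C=C/c2ccc(OC)c(OCc3cn(-c4ccc(F)cc4Cl)nn3)c2)c(OC)c1` gives in this assay > 100 ug/mL, again a limit.

Compound 1 and compound 2 share one core. Compound 3 is built on another core, and the difference between the two cores is not broken down here. Within the first core, the single change is 4-chlorophenyl in place of 2-chloro-4-fluorophenyl on an aromatic nitrogen. The step that the two limits leave unreadable from compound 2 to compound 1 cannot be sized because of the limit of > 100 ug/mL in this assay, at which 3 of the 3 values shown sit.

The unmeasured compound 4 `COc1cc(O)c(C(=O)/C=C/c2ccc(OC)c(OCc3cn(-c4ccc(Cl)cc4)nn3)c2)c(OC)c1` carries the same change on the core of compound 3: 4-chlorophenyl in place of 2-chloro-4-fluorophenyl on an aromatic nitrogen. The surroundings of the change read word for word the same in both pairs, so it is the same change, not merely the same kind.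

For compound 4 the expected step is a step that the limit leaves unreadable from compound 3 to compound 4, in effect no readable change. That expectation rests on compound 3 sitting at its limit > 100 ug/mL. It also rests on the unreadable step that the two limits leave unreadable from compound 2 to compound 1 in the first core. Compound 4 is therefore estimated at 150 ug/mL, with a likely range from 80 ug/mL to 300 ug/mL, most probably reported only as a limit again.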

Compound 4, half-maximal cytotoxic concentration: > 100 ug/mL
Compound 4: only a limit was reported; the forecaster's own chance of this, stated with the estimate: 85%; the middle value is on the limit's open side.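

In this assay compound 4 gives > 100 ug/mL as a limit of the assay. No step from compound 3 to compound 4 can be read, because both compounds sit at the same limit: the limit of > 100 ug/mL in this assay, at which 4 of the 4 values shown sit.

The compounds shown leave open how far the tolerated concentrations lie past that limit, and whether the swap from 2-chloro-4-fluorophenyl to 4-chlorophenyl shifts them on either core.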